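Fluoro Added Para, Once More, on a Methylated Sulfonamide

A few compounds are considered here, and "the series" means these few. Any claim that something is new, unique, unknown or untested is made for them only; others in the source may bear on it.

Measured so far:
Compound 1 `O=S(=O)(Nc1ccccc1)c1ccccc1` gives 9.1 in an ADME assay.
Compound 2 `O=S(=O)(Nc1ccc(F)cc1)c1ccccc1` gives 8.85.
Compound 3 `Cc1ccc(NS(=O)(=O)c2ccccc2)cc1` gives 9.34.

Compound 3 stands highest of the three, but its gap to compound 1 is within the scatter: a number 0.24 log units higher from compound 1 to compound 3 (within the scatter). From compound 2 the gap is larger: a number 0.49 log units higher from compound 2 to compound 3 (beyond the scatter).

Compound 4 `Cc1ccc(NS(=O)(=O)c2ccc(F)cc2)cc1` is still unmeasured. It differs from compound 3 by fluoro in place of hydrogen on an aromatic carbon. The same change has been made once before, from compound 1 to compound 2: fluoro in place of hydrogen on an aromatic carbon, and there it gave a number 0.25 log units lower from compound 1 to compound 2 (within the scatter). The two cores differ by methyl in place of hydrogen on an aromatic carbon; the place of the fluoro is described in the same words in both pairs, so this is the same change.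

For compound 4 the step from compound 3 is expected to be a number 0.24 log units lower from compound 3 to compound 4 (within the scatter), resting on a number 0.25 log units lower from compound 1 to compound 2 (within the scatter) seen between compound 1 and compound 2. Compound 4 is therefore estimated at 9.1, between 8.8 and 9.4.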

Compound 4, acid dissociation constant: 9.23
Estimate against measurement, compound 4: 0.13 log units below; measured number inside the range.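

In this assay the step of a number 0.11 log units lower from compound 3 to compound 4 (within the scatter) comes from fluoro in place of hydrogen on an aromatic carbon. Set beside the earlier case, the change gives steps that cannot be told apart on these two cores: the same change on two cores in this assay, a number 0.25 log units lower (within the scatter) from compound 1 to compound 2 and a number 0.11 log units lower (within the scatter) from compound 3 to compound 4, 0.14 log units apart, within the scatter of two such steps. This agreement fits carrying the change from one core to the other, but both steps are small enough to lie within the scatter, so it does not show that fluoro really shifts the number on either core, and two cores do not make a rule for the series.

The compounds shown leave open how a chloro, a nitrile or an amine in place of that hydrogen would behave. They also leave open whether fluoro would give a similar step on a core with a longer chain in place of the methyl.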